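The compounds below may be only part of what the source reports. "The series", "measured", "known", "first", "only" and "open" are said of these compounds alone.

Compound 1 `Cc1cccc(NC(=O)CSC(=S)N[C@H]2CCOC2=O)c1` gives in a functional assay on EC9706 cells (Homo sapiens) for cytotoxicity, read by MTT assay, with a stated time of 72 h (a higher number here means a weaker inhibitor, a lower number a stronger inhibitor), only a limit, > 128000 nM.
Compound 2 `O=C(CSC(=S)N[C@H]1CCOC1=O)Nc1cccc([N+](=O)[O-])c1` gives in this assay only a limit, > 128000 nM.
Compound 3 `O=C(CCl)Nc1ccc(C(=O)/C=C/c2ccc([N+](=O)[O-])cc2)cc1` gives in this assay the value 3670 nM.

Compound 1 and compound 2 share a core and differ by methyl in place of nitro on an aromatic carbon. Since both sit at the limit of > 128000 nM in this assay, at which 2 of the 3 values shown sit, the step that the two limits leave unreadable from compound 2 to compound 1 cannot be read. Compound 3 has a different core, and the difference between the two cores is not broken down here; compound 3 is the only one of the three with a number in this assay.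

Compound 4 `Cc1ccc(/C=C/C(=O)c2ccc(NC(=O)CCl)cc2)cc1` is not yet measured. It differs from compound 3 by methyl in place of nitro on an aromatic carbon. This is the same kind of change as that from compound 2 to compound 1, but not the same: there the methyl stands meta to a large group, here para to a large group.

Because the step that the two limits leave unreadable from compound 2 to compound 1 gives no readable size, the step from compound 3 to compound 4 is expected to be small, a 1.2-fold higher number from compound 3 to compound 4 (0.09 log units; within the scatter). Compound 4 is therefore expected at 4500 nM, between 1200 nM and 25000 nM, resting on compound 3 at 3670 nM.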

Compound 4, half-maximal inhibitory concentration: 7150 nM
Estimate against measurement, compound 4: 1.6-fold (0.20 log units) below; the range from low to high includes it.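

On the core of compound 3, methyl in place of nitro on an aromatic carbon, para to a large group, gives in this assay a 1.9-fold higher number from compound 3 to compound 4 (0.29 log units; within the scatter), so on this core the exchange of the two groups leaves the result within the usual scatter of the measurement. This does not show that the change carries from one core to another, since this is the only readable step of its kind among the compounds shown. The same exchange on the core of compound 1 gives no size that could be set beside it, because compound 1 and compound 2 both rest on a limit and not on a number: the limit of > 128000 nM in this assay, at which 2 of the 4 values shown sit.

From the compounds shown here alone, it remains open whether an amine or a carboxylic acid on that same aromatic carbon would also stay within the scatter of compound 3, and what an ethyl group or a longer chain in place of the methyl would give. Going by these compounds, it also remains open whether any group on the ring of the core of compound 1 would bring a number in this assay at all.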